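The source may hold more compounds than are shown below. What is called first, only, known or untested is meant among the compounds shown, and "the series" means these compounds.

Three compounds have been measured in an assay on cells for displacement of a labelled ligand from adenosine receptor A1 (Homo sapiens), read by scintillation counting and radioligand binding, with a stated time of 60 min, tested at 10 uM; on this read-out lower numbers stand for less inhibition and higher numbers for more inhibition at the one concentration tested (going by the name of the read-out):

compound 1 `CN1CCN(c2nc(-c3ccc(Cl)cc3)nc3[nH]cnc23)CC1`, > 80%
compound 2 `Clc1cccc(-c2nc(N3CCCCC3)c3nc[nH]c3n2)c1`, > 80%
compound 3 `CN1CCN(c2nc(-c3cccc(Cl)c3)nc3c2ncn3C)CC1`, 45.7%

Compound 2 does not give a number in this assay but only a limit, > 80%. The same holds for compound 1, which also stops at a limit, > 80%. Compound 2 therefore stands at the ceiling of the read-out, (the limit of > 80% in this assay, at which 2 of the 3 values shown sit). Within the data shown here, compound 3 gives a plain number, 45.7%, but compound 3 and compound 2 differ in more than one spot, so no single step joins them and the two values can only be set side by side.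

Compound 4 `Oc1cccc(-c2nc(N3CCCCC3)c3nc[nH]c3n2)c1` has not yet been measured. It differs from compound 2 in one place only: hydroxy in place of chloro on an aromatic carbon. Among the measured compounds shown here, no measured pair in this set carries the same change, so its size in this assay cannot be read off. The expectation is a moderate loss, with the step of a number at least 20 percentage points lower from compound 2 to compound 4 (beyond the scatter). Compound 4 is thus estimated at 60%, within a range from 25% to 85%.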

Compound 4, a percentage reported as inhibition, at one concentration (the size of the read-out at that concentration, not a potency): > 80%
Compound 4: only a limit was reported (the forecaster's own chance of this, stated with the estimate: 25%); middle value at least 20 percentage points from the limit.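

Compound 2 and compound 4 both give only a limit in this assay, so no step between them can be read: the limit of > 80% in this assay, at which 3 of the 4 values shown sit.

The compounds shown leave open whether hydroxy in place of chloro changes the inhibition at all, and if so, in which direction.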